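The source may hold more compounds than are shown below. What is called first, only, known or untested is meant among the compounds shown, and "the series" means these compounds.

Three compounds measured in a functional assay on 3T3-L1 cells (Mus musculus) for inhibition, with a stated time of 20 min, tested at 20 uM (a higher number here means more inhibition at the concentration tested (going by the name of the read-out), a lower number less inhibition), set the scene. Compound 1 `Cc1ccc(S(=O)(=O)N(Cc2cn(Cc3ccccc3Cl)nn2)Cc2cn(S(=O)(=O)c3ccc(C)cc3)c3ccccc23)cc1` gives -4.8% in this assay, the second highest of the three numbers. Compound 2 `CC(=O)N(Cc1cn(Cc2cccc(F)c2F)nn1)Cc1cn(S(=O)(=O)c2ccc(C)cc2)c2ccccc12` gives 39.5% in this assay, which lies beyond the scatter above compound 1. Compound 3 `O=C(N(Cc1cccc(F)c1F)Cc1cn(S(=O)(=O)c2ccc(F)cc2)c2ccccc12)C(F)(F)F` gives -52.3% in this assay, beyond the scatter below compound 1. The three differ in several places at once, so no single change among them can be read from these values.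

Compound 4 `Cc1ccc(S(=O)(=O)N(Cc2cn(Cc3ccccc3)nn2)Cc2cn(S(=O)(=O)c3ccc(C)cc3)c3ccccc23)cc1` has not yet been measured. It differs from compound 1 in one place only: hydrogen in place of chloro on an aromatic carbon. For the measured compounds named here, no measured pair shows what removing a chloro of this kind does here, so the direction of the step is open. A small step in this assay is expected, likely within the usual scatter, giving an expected step of a number 1.8 percentage points higher from compound 1 to compound 4 (within the scatter). Compound 4 is therefore expected to give about -3% in this assay, with a range from -30% to 25%.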

Compound 4, a percentage reported as inhibition, at one concentration (the size of the read-out at that concentration, not a potency): 3.4%
Compound 4: middle estimate off by 6.4 percentage points, on the low side; the measured number falls inside the stated range.
By their numbers in this assay, from the lowest: compound 3; then compounds 1 and 4 (each within the scatter of the next); then compound 2.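

Taking the chloro off this aromatic carbon, which turns 2-chlorobenzyl into benzyl, gives a number 8.2 percentage points higher from compound 1 to compound 4 (within the scatter) in this assay. For the compounds shown here, this is the first comparison in the set that isolates a single change, and it shows that compound 1 and compound 4 cannot be told apart in this read-out, so this one step gives no sign that the chloro at this position matters. Nothing at hand offers an explanation for the size of this step.

The compounds shown leave open whether a different group on this aromatic carbon, such as a methoxy group or an amine, would give a step beyond the scatter. They also leave open whether removing a chloro would give a similar step on another aromatic carbon of that ring, or on a different sulfonamide or amide partner.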